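Replacing Furan-2-yl with Pyridin-2-yl

The compounds below may be only part of what the source reports. "The series", "measured", "known", "first", "only" and "open" are said of these compounds alone.

In a functional assay on MCF7 cells (Homo sapiens) for inhibition, with a stated time of 96 h (on this read-out higher numbers stand for weaker inhibition and lower numbers for stronger inhibition), compound 1 (`COc1cc(C(=O)c2cn(-c3cccc(C)c3)cc2-c2ccco2)cc(OC)c1OC`) reads 23 nM and compound 2 (`COc1cc(C(=O)c2cn(-c3ccc(C)cc3)cc2-c2ccco2)cc(OC)c1OC`) reads 22 nM while compound 3 (`COc1cc(C(=O)c2cn(-c3ccc(F)cc3)cc2-c2ccco2)cc(OC)c1OC`) reads 17 nM which places compound 2 within the scatter of both others. Compound 4 (`COc1cc(C(=O)c2cn(-c3ccc(C)cc3)cc2-c2ccccn2)cc(OC)c1OC`) differs from compound 2 by one swap (pyridin-2-yl in place of furan-2-yl on an aromatic carbon) with pyridin-2-yl in place of furan-2-yl on an aromatic carbon. The three measured steps are all small: a 1.0-fold lower number from compound 1 to compound 2 (0.02 log units; within the scatter) and a 1.4-fold lower number from compound 1 to compound 3 (0.13 log units; within the scatter) and also a 1.3-fold lower number from compound 2 to compound 3 (0.11 log units; within the scatter) concern only the aryl group on the nitrogen. None touches the furan-2-yl site, so they offer no direct guide. A modest estimated move toward weaker inhibition (a 1.8-fold higher number from compound 2 to compound 4 (0.26 log units; within the scatter)) is therefore only a cautious expectation. In this assay the estimated value for compound 4 is 40 nM (expected range 12 nM to 150 nM).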

Compound 4, half-maximal inhibitory concentration: 36 nM
Compound 4: the middle estimate sits 1.1-fold (0.05 log units) above what was measured, and the stated range covers the measured number.
By their numbers in this assay, from the lowest: compounds 3, 2, 1 and 4 (each within the scatter of the next, the first and the last beyond it).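

This is the first change shown at the site on the five-membered aromatic ring, and in this assay swapping furan-2-yl for pyridin-2-yl gives a 1.6-fold higher number from compound 2 to compound 4 (0.21 log units; within the scatter). For this pair, then, a six-membered aromatic ring at this position reads the same as a five-membered one, within the scatter. Nothing available here speaks to the reason for this result.

On these data alone, whether an open-chain group such as an amine or a propyl chain would read alike at this position remains open. So does whether the same swap holds with 4-fluorophenyl in place of 4-methylphenyl.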